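Methylsulfanyl for trifluoromethyl on the shared core

A few compounds are considered here, and "the series" means these few. Any claim that something is new, unique, unknown or untested is made for them only; others in the source may bear on it.

compound 1 `S=C(Nc1ccccc1)N1N=C(c2ccc(Br)cc2)CC1c1ccc2c(c1)OCCO2`: 2580 nM
compound 2 `FC(F)(F)c1ccc(C2=NN(C(=S)Nc3ccccc3)C(c3ccc4c(c3)OCCO4)C2)cc1`: 97500 nM

Both compounds have been run in a functional assay on HT-29 cells (Homo sapiens) for antiproliferative activity, read by MTT assay, with a stated time of 48 h; a lower number here means a stronger inhibitor of growth, a higher number a weaker inhibitor of growth. Within the data shown here, compound 2 stands at the highest number of the two; the only measured step, a 38-fold higher number from compound 1 to compound 2 (1.58 log units; beyond the scatter), is large and beyond the scatter, so compound 1 is clearly the stronger inhibitor of growth in this assay.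

Compound 3 `CSc1ccc(C2=NN(C(=S)Nc3ccccc3)C(c3ccc4c(c3)OCCO4)C2)cc1` has not been measured. It differs from compound 2 by methylsulfanyl in place of trifluoromethyl on an aromatic carbon. Among the measured compounds shown here, no measured step covers methylsulfanyl; the single step on record concerns bromo against trifluoromethyl at the same place, and it shows the trifluoromethyl compound at a much higher number. This gives only indirect guidance: the ring position tolerates a wide spread of values, and compound 2 marks the weak end. Compound 3 is expected at 12000 nM in this assay, with a range from 2500 nM to 60000 nM. For compound 3 the expected step is an 8.1-fold lower number from compound 2 to compound 3 (0.91 log units; beyond the scatter).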

Compound 3, concentration for 50% growth inhibition: > 200000 nM
Compound 3 ended at the assay's limit; the forecaster's own chance of this, stated with the estimate: 10%; at least 16-fold (1.22 log units) between middle value and limit.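

In this assay compound 3 stands at a limit and not at a number: the limit of > 200000 nM in this assay, at which 1 of the 3 values shown sits. Trifluoromethyl therefore no longer marks the weak end at this place, since methylsulfanyl gives an at least 2.0-fold higher number from compound 2 to compound 3 (0.31 log units; beyond the scatter), and the distance from the bromo compound widens to an at least 77-fold higher number from compound 1 to compound 3 (1.88 log units; beyond the scatter). Among these three compounds the order at the aromatic carbon runs bromo, then trifluoromethyl, then methylsulfanyl, with growth inhibition falling along it, and both steps into compound 3 are lower bounds whose true size stays unknown.

The compounds shown leave open whether any group at this place improves on bromo, for instance chloro, methoxy or an amine. They also leave open whether the same order would hold with a group other than phenyl on the thiourea nitrogen of the shared core.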